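This account rests on a few compounds, and the source may have more. Where it says the series, first, only, none or still open, it means among the compounds named here.

Compound 1 `Fc1ccc2nc(-c3cccnc3)[nH]c2c1` gives 1990 nM in an assay on V79 cells for inhibition of cytochrome P450 11B1, mitochondrial (Homo sapiens), read by HTRF, with a stated time of 1 h; on this read-out lower numbers stand for stronger inhibition and higher numbers for weaker inhibition.
Compound 2 `CCn1c(-c2cccnc2)nc2ccc(F)cc21` gives 2100 nM in this assay.

Going by the values given here, compound 2 is one of only two compounds measured so far, and its number lies within the usual scatter of that of compound 1: the step of a 1.1-fold higher number from compound 1 to compound 2 (0.02 log units; within the scatter) is too small to count as a change. Compound 3 `Fc1ccc2nc(-c3cccnc3)n(C3CCC3)c2c1` has not been measured. It differs from compound 2 in one place: cyclobutyl in place of ethyl on an aromatic nitrogen.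

Among the compounds with values here, only one measured step bears on this change, and only loosely. The step of a 1.1-fold higher number from compound 1 to compound 2 (0.02 log units; within the scatter) shows that replacing the hydrogen on that aromatic nitrogen with an ethyl left the number where it was. Within the data shown here, no measured pair speaks to a cyclobutyl on that nitrogen, so the effect of the larger ring is unknown. On the evidence at hand the estimated step of a 1.1-fold lower number from compound 2 to compound 3 (0.04 log units; within the scatter) is expected to stay within the scatter, with wide uncertainty on either side. Compound 3 is therefore estimated at 1900 nM in this assay, with a range from 600 nM to 6000 nM.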

Compound 3, half-maximal inhibitory concentration: > 10000 nM
Compound 3: a limit, no number (the forecaster's own chance of this, stated with the estimate: 10%); at least 5.2-fold (0.72 log units) between middle value and limit.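

In this assay compound 3 stands at a limit of the assay, not at a number: the limit of > 10000 nM in this assay, at which 1 of the 3 values shown sits.

This shows that the aromatic nitrogen is not indifferent to what it carries. Going by these compounds alone, the earlier pair left hydrogen and ethyl within the scatter, a 1.1-fold higher number from compound 1 to compound 2 (0.02 log units; within the scatter), whereas the cyclobutyl gives an at least 4.7-fold higher number from compound 2 to compound 3 (0.67 log units; beyond the scatter) and an at least 5.0-fold higher number from compound 1 to compound 3 (0.70 log units; beyond the scatter), so the first change at this position that can be read is a loss of inhibition. Both new steps end at the limit, so they fix only a minimum for that loss and leave its full size unread.

The three compounds leave open whether the loss goes with the ring itself or with the larger number of carbons, and a cyclopropyl, a propyl chain or an open butyl chain on the same nitrogen would separate the two. They also leave open how a longer chain ending in an amine or a hydroxyl group would read at this position.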